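Changing the aryl group of compound 3

The compounds below may be only part of what the source reports. "The series", "measured", "known", "first", "only" and "open" are said of these compounds alone.

Compound 1 `NC1CCc2nc(-c3ccncc3)nc(Nc3ccc(F)cc3)c2C1` gives 20800 nM
Compound 2 `NC1CCc2nc(-c3ccncc3)nc(Nc3cccc(F)c3)c2C1` gives 17000 nM
Compound 3 `CN(C)c1ccc(Nc2nc(-c3ccncc3)nc3c2CC(N)CC3)cc1` gives 38200 nM

In a functional assay on HeLa cells (Homo sapiens) for antiproliferative activity, read by MTT assay, with a stated time of 72 h (a lower number here means a stronger inhibitor, a higher number a weaker inhibitor), compound 3 lies within the scatter of compound 1 (a 1.8-fold higher number from compound 1 to compound 3 (0.26 log units; within the scatter)) and modestly above compound 2 (a 2.2-fold higher number from compound 2 to compound 3 (0.35 log units; beyond the scatter)). Compound 4 `COc1cccc(Nc2nc(-c3ccncc3)nc3c2CC(N)CC3)c1` differs in one place (3-methoxyphenyl in place of 4-(dimethylamino)phenyl on a nitrogen on an aromatic ring) with 3-methoxyphenyl in place of 4-(dimethylamino)phenyl on a nitrogen on an aromatic ring. The closest measured change is the swap between 3-fluorophenyl and 4-(dimethylamino)phenyl (a 2.2-fold higher number from compound 2 to compound 3 (0.35 log units; beyond the scatter)), and the swap between 4-fluorophenyl and 3-fluorophenyl was smaller (a 1.2-fold lower number from compound 1 to compound 2 (0.09 log units; within the scatter)). A small step to a lower number is therefore expected (a 1.7-fold lower number from compound 3 to compound 4 (0.24 log units; within the scatter)). In this assay the estimate for compound 4 is 22000 nM (expected range 10000 nM to 48000 nM).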

Compound 4, half-maximal inhibitory concentration: 17200 nM
Compound 4: the middle estimate sits 1.3-fold (0.11 log units) above what was measured; the range from low to high includes it.
By their numbers in this assay, from the lowest: compounds 2, 4, 1 and 3 (each within the scatter of the next, the first and the last beyond it).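

In this assay, methoxy in place of fluoro leaves the number unchanged within the scatter (a 1.0-fold higher number from compound 2 to compound 4 (0.01 log units; within the scatter)), so 3-methoxyphenyl cannot be told apart from 3-fluorophenyl on this nitrogen. Nor can it be told apart from 4-fluorophenyl (a 1.2-fold lower number from compound 1 to compound 4 (0.08 log units; within the scatter)). The step from 4-(dimethylamino)phenyl is modest (a 2.2-fold lower number from compound 3 to compound 4 (0.35 log units; beyond the scatter)), and compound 1 goes against any clean separation of that group, since it stays within the scatter of compound 3.

As far as these compounds go, whether 4-methoxyphenyl, a carboxylic acid or a longer chain at this place would leave this narrow band remains open. No evidence at hand explains the modest step.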